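The source may report more compounds than this note shows. Statements on the series, on what has been measured and on what is new or still open speak of the compounds shown alone.

Series notes, aryl group on the shared core.

Compound 1 `COc1ccc(S(=O)(=O)N2CCc3cccc(-c4ccncc4)c32)cc1` gives 106 nM in a functional assay on KB-VIN10 cells (Homo sapiens) for inhibition, with a stated time of 72 h; a lower number here means a stronger inhibitor, a higher number a weaker inhibitor. Compound 2 `COc1ccc(S(=O)(=O)N2CCc3cccc(-c4cccs4)c32)cc1` gives 251 nM and so stands highest of the two numbers; the step of a 2.4-fold higher number from compound 1 to compound 2 (0.37 log units; beyond the scatter) is the only one measured so far, and it reflects thiophen-2-yl in place of pyridin-4-yl on an aromatic carbon.

Compound 3 `COc1ccc(S(=O)(=O)N2CCc3cccc(-c4ccccc4)c32)cc1` is not yet measured. Its change from compound 2 is phenyl in place of thiophen-2-yl on an aromatic carbon. Within the data shown here, no measured step covers this exact exchange; the step from compound 1 to compound 2 bears on it only in that it shows the aryl group at this position moving the number by a modest amount. Compound 3 is therefore expected to sit close to compound 2, with at most a small step of a 1.4-fold lower number from compound 2 to compound 3 (0.14 log units; within the scatter) toward a lower number and possibly none beyond the scatter. The estimate for compound 3 is 180 nM, with a range from 70 nM to 450 nM.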

Compound 3, half-maximal inhibitory concentration: 107 nM
Compound 3: middle estimate off by 1.7-fold (0.23 log units), on the high side; low and high end bracket the measured number.
By their numbers in this assay, from the lowest: compounds 1 and 3 (each within the scatter of the next); then compound 2.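

Phenyl in place of thiophen-2-yl on this aromatic carbon gives a 2.3-fold lower number from compound 2 to compound 3 (0.37 log units; beyond the scatter), while phenyl in place of pyridin-4-yl gives a 1.0-fold higher number from compound 1 to compound 3 (0.00 log units; within the scatter), so the carbon-only ring and pyridin-4-yl cannot be told apart here. Among these three compounds, only the five-membered thiophen-2-yl of compound 2 stands apart from the two six-membered rings, although a single five-membered example cannot show whether ring size is what matters. Nothing available explains the difference between these aryl groups.

From the compounds shown here alone, it remains open whether another five-membered ring, such as furan-2-yl or thiophen-3-yl, would track with compound 2. Also open, going by these compounds, is how the number would respond to an amine or a carboxylic acid on the phenyl ring, or to a saturated ring such as cyclohexyl at this carbon.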